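This account rests on a few compounds, and the source may have more. Where it says the series, first, only, none or still open, it means among the compounds named here.

Compound 1 `COc1cc(C(=O)NS(=O)(=O)c2ccccc2Cl)ccc1Cn1ccc2ccc(NC(=O)CC3CCCC3)cc21` and compound 2 `COc1cc(C(=O)NS(=O)(=O)c2ccccc2C)ccc1Cn1ccc2ccc(NC(=O)CC3CCCC3)cc21` share one core and differ in one place only. In a functional assay (trachea) for antagonist activity, with Cavia porcellus as the target (a higher number here means a more potent compound, by a factor of ten per unit of this negative logarithm, a lower number a less potent compound), compound 1 gives 9.8; in this assay compound 2 gives 9.9. The step of a number 0.10 log units higher from compound 1 to compound 2 (within the scatter) is the only one measured so far, so compound 2 stands together with compound 1, the two numbers not set apart from each other. Compound 3 `COc1cc(C(=O)NS(=O)(=O)c2cc(C)ccc2C)ccc1Cn1ccc2ccc(NC(=O)CC3CCCC3)cc21` carries a further change on the same part of the molecule: methyl in place of hydrogen on an aromatic carbon. Among the compounds with values here, no measured step touches this position; the one step that exists swaps one group for another rather than adding a new one, and so it bears only loosely on an added methyl. With nothing pointing either way, no step beyond the scatter is expected in this assay. Compound 3 is therefore estimated at 9.8, with a range from 9.2 to 10.3. The expected step of a number 0.10 log units lower from compound 2 to compound 3 (within the scatter) is accordingly small.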

Compound 3, negative logarithm of the antagonist equilibrium constant: 8.4
Compound 3: the middle estimate sits 1.40 log units above what was measured, and the stated range ends above it.
By their numbers in this assay, from the lowest: compound 3; then compounds 1 and 2 (each within the scatter of the next).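

In this assay, the aromatic ring on the sulfonyl group responds very differently to two kinds of change. Exchanging 2-chlorophenyl for 2-methylphenyl gives a number 0.10 log units higher from compound 1 to compound 2 (within the scatter), whereas adding a methyl para to the existing methyl group gives a number 1.50 log units lower from compound 2 to compound 3 (beyond the scatter), and the full change to 2,5-dimethylphenyl gives a number 1.40 log units lower from compound 1 to compound 3 (beyond the scatter), so this one carbon is far more sensitive to substitution than the earlier pair suggested. No data here account for this loss of potency.

As far as these compounds go, whether the loss is specific to methyl or follows any group at this carbon remains open, as a fluoro, an amine or a carboxylic acid there would show. Also open, from the compounds shown here alone, is whether the same methyl costs as much when chloro, rather than methyl, occupies the other ring position.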